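Swapping a difluorophenyl ether for a pyridyl ether

This account rests on a few compounds, and the source may have more. Where it says the series, first, only, none or still open, it means among the compounds named here.

Measured so far:
compound 1 `Cc1c(OCCCCOc2ccccc2F)ccc(C(=O)CC(C)C)c1O` gives 1990 nM in a functional assay for binding affinity to metabotropic glutamate receptor 2 (Homo sapiens), read by GTPgammaS binding; on this read-out higher numbers stand for an effect only at larger amounts of compound and lower numbers for an effect already at smaller amounts
compound 2 `Cc1c(OCCCCOc2cccc(F)c2F)ccc(C(=O)CC(C)C)c1O` gives 384 nM in this assay

Going by the values given here, compound 2 has the lower of the two numbers; its only neighbour is compound 1, and the step of a 5.2-fold lower number from compound 1 to compound 2 (0.71 log units; beyond the scatter) came from a single added fluorine on the aromatic ring at the end of the chain. Compound 3 `Cc1c(OCCCCOc2cccnc2)ccc(C(=O)CC(C)C)c1O` differs from compound 2 by pyridin-3-yl in place of 2,3-difluorophenyl on an oxygen on a saturated carbon. Among the compounds with values here, the one measured step bears on this only in part: it shows that removing a fluorine from that ring tends to raise the number, but nothing measured speaks to replacing a ring carbon by nitrogen. Both fluorines leave in compound 3, so a step upward is expected, perhaps larger than the scatter, giving a 3.9-fold higher number from compound 2 to compound 3 (0.59 log units; beyond the scatter). For compound 3 the estimate is 1500 nM, within a range from 400 nM to 6000 nM.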

Compound 3, half-maximal effective concentration: 1720 nM
Estimate against measurement, compound 3: 1.1-fold (0.06 log units) below, within the range that was stated.
By their numbers in this assay, from the lowest: compound 2; then compounds 3 and 1 (each within the scatter of the next).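

In this assay, going by these compounds alone, the earlier compounds showed only a change in fluorine on this ring, whereas the ring itself now changes: pyridin-3-yl in place of 2,3-difluorophenyl gives a 4.5-fold higher number from compound 2 to compound 3 (0.65 log units; beyond the scatter) and so does not keep the gain that came with the added fluorine. Pyridin-3-yl in place of 2-fluorophenyl gives a 1.2-fold lower number from compound 1 to compound 3 (0.06 log units; within the scatter) and so leaves these two groups indistinguishable on this read-out. No measurement at hand explains either step.

Going by these compounds, it remains open whether a fluorine placed on the pyridine ring would bring the number back toward that of compound 2. On these data alone, it is also open how pyridin-2-yl, pyridin-4-yl or a phenyl ring carrying an amine or a carboxylic acid would behave on this oxygen.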